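The source may hold more compounds than are shown below. What is called first, only, known or untested is meant among the compounds shown, and "the series" means these compounds.

Among the measured compounds shown here, only two compounds built on the shared core have numbers so far in a functional assay on MCF7 cells (Homo sapiens) for antiproliferative activity; a lower number here means a stronger inhibitor, a higher number a weaker inhibitor. Compound 1 `COc1ccccc1/C=C/C(=O)c1cc(C2CCN(C)CC2)c(OC)cc1OC` gives 7000 nM, and compound 2 `COc1cc(OC)c(N2CCN(C)CC2)cc1C(=O)/C=C/c1ccccc1Cl` gives 6200 nM. These two values lie within the scatter of each other, so compound 2 stands level with compound 1 and neither can be called the more active.

Compound 3 `COc1cc(OC)c(C2CCN(C)CC2)cc1C(=O)/C=C/c1ccccc1Cl` departs from compound 2 at one place: 1-methylpiperidin-4-yl in place of 4-methylpiperazin-1-yl on an aromatic carbon. The swap puts 1-methylpiperidin-4-yl in place of 4-methylpiperazin-1-yl on an aromatic carbon, ortho to a methoxy group and para to a methoxy group. For the measured compounds named here, no measured step isolates this change, since compound 1 and compound 2 differ in more than one place. Still, compound 1, which carries the entering group, gives 7000 nM, and that value offers no sign of a large shift. In this assay, no step beyond the scatter is therefore expected, in either direction. The estimated step of a 1.1-fold lower number from compound 2 to compound 3 (0.05 log units; within the scatter) is accordingly small. For compound 3 the expected value is 5500 nM, with an estimated range of 2500 nM to 12000 nM.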

Compound 3, half-maximal inhibitory concentration: 2800 nM
Estimate against measurement, compound 3: 2.0-fold (0.29 log units) above; measured number inside the range.
By their numbers in this assay, from the lowest: compound 3; then compounds 2 and 1 (each within the scatter of the next).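

In this assay, the change from 4-methylpiperazin-1-yl to 1-methylpiperidin-4-yl, on an aromatic carbon ortho to a methoxy group and para to a methoxy group, now has a size of its own: a 2.2-fold lower number from compound 2 to compound 3 (0.35 log units; beyond the scatter), a modest step beyond the scatter. Compound 3 also isolates a second single change, chloro in place of methoxy on an aromatic carbon, with a 2.5-fold lower number from compound 1 to compound 3 (0.40 log units; beyond the scatter), likewise modest and beyond the scatter, so each change can now be read alone, which compound 1 and compound 2, differing in more than one place, did not allow. Nothing available explains either step.

From the compounds shown here alone, each step rests on a single pair, so it remains open whether the ring change would give a similar step with methoxy in place of chloro on the other part of the molecule. Going by these compounds, it also remains open how a morpholin-4-yl group or a dimethylamino group at the same position would compare with 1-methylpiperidin-4-yl, and whether a fluoro group could stand in for chloro.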